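This account rests on a few compounds, and the source may have more. Where it says the series, first, only, none or still open, it means among the compounds named here.

Series notes. Compound 3 `Nc1ccc(S(=O)(=O)N2CCN(c3ncc(C(O)(C(F)(F)F)C(F)(F)F)cc3-c3cccc(F)c3)CC2)cn1` gives 52 mL.min-1.g-1 in an ADME assay (liver) for metabolic stability, with Liver microsome (Rattus norvegicus) as the target, using microsomes and NADPH, with a stated time of 30 min, tested at 1 uM (on this read-out lower numbers stand for slow clearance and higher numbers for fast clearance), the lowest of the two numbers measured; compound 2 `Cc1csc(-c2cc(C(O)(C(F)(F)F)C(F)(F)F)cnc2N2CCN(S(=O)(=O)c3ccc(N)nc3)CC2)c1` gives 399 mL.min-1.g-1, a step of a 7.7-fold lower number from compound 2 to compound 3 (0.88 log units; beyond the scatter). Compound 1 `COc1cc(C(O)(C(F)(F)F)C(F)(F)F)cnc1N1CCN(S(=O)(=O)c2ccc(N)nc2)CC1` gives only a limit in this assay, < 14 mL.min-1.g-1, which is the limit of < 14 mL.min-1.g-1 in this assay, at which 1 of the 3 values shown sits. From compound 1 the steps are an at least 28-fold higher number from compound 1 to compound 2 (1.45 log units; beyond the scatter) and an at least 3.7-fold higher number from compound 1 to compound 3 (0.56 log units; beyond the scatter).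

Compound 4 `Cc1ccc(-c2cc(C(O)(C(F)(F)F)C(F)(F)F)cnc2N2CCN(S(=O)(=O)c3ccc(N)nc3)CC2)cn1` differs from compound 3 in one place: 6-methylpyridin-3-yl in place of 3-fluorophenyl on an aromatic carbon. For the measured compounds named here, no measured step exchanges one six-membered aromatic ring for another; the nearest is the exchange of 4-methylthiophen-2-yl for 3-fluorophenyl, a 7.7-fold lower number from compound 2 to compound 3 (0.88 log units; beyond the scatter), which was modest. The 6-methylpyridin-3-yl group entering here carries a methyl like the 4-methylthiophen-2-yl of compound 2, yet a six-membered aromatic ring with 1 hetero atom is not represented among the measured compounds, so the direction rests on little. The step is expected to be small, a 1.5-fold lower number from compound 3 to compound 4 (0.17 log units; within the scatter), within or close to the scatter and leaning lower. Compound 4 is estimated at 35 mL.min-1.g-1 in this assay, with a range from 12 mL.min-1.g-1 to 100 mL.min-1.g-1.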

Compound 4, intrinsic clearance in microsomes: 182 mL.min-1.g-1
For compound 4 the middle estimate is 5.2-fold (0.72 log units) below the measured one; measured number outside the range, above it.
By their numbers in this assay, from the lowest: compound 3; then compound 4; then compound 2. At a limit, below all of these: compound 1.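

Exchanging one six-membered aromatic ring for another at this position still moves the number in this assay (a 3.5-fold higher number from compound 3 to compound 4 (0.54 log units; beyond the scatter)), so having such a ring here does not by itself settle the clearance read-out. Compound 4 also stands apart from compound 2 (a 2.2-fold lower number from compound 2 to compound 4 (0.34 log units; beyond the scatter)), and both groups that carry a methyl give higher numbers than the 3-fluorophenyl of compound 3, a pattern resting on these three compounds alone. Against methoxy, 6-methylpyridin-3-yl also gives a higher number (an at least 13-fold higher number from compound 1 to compound 4 (1.11 log units; beyond the scatter)), and that step starts from a limit for compound 1: the limit of < 14 mL.min-1.g-1 in this assay, at which 1 of the 4 values shown sits.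

Whether the methyl or the ring nitrogen of 6-methylpyridin-3-yl accounts for the step stays open, as plain pyridin-3-yl and plain phenyl are absent from the compounds shown. Also open, from the compounds shown here alone, is where an amine or a longer alkoxy chain at this position would fall relative to methoxy and the aromatic rings.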